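This account rests on a few compounds, and the source may have more. Where it says the series, first, only, none or still open, it means among the compounds named here.

In a functional assay on A549 cells (Homo sapiens) for inhibition, read by MTT assay, with a stated time of 48 h (on this read-out lower numbers stand for stronger inhibition and higher numbers for weaker inhibition), compound 1 `COc1ccc(N(C)c2nc(C)nc3ccccc23)cc1C(=O)OCC[Se]C#N` gives 353 nM. That is the higher of the two numbers available, so compound 1 is the weaker inhibitor of the pair, and the gap to compound 2 `Cc1nc(N(C)c2ccc([Se]C#N)c(C)c2)c2ccccc2n1`, which gives 8 nM, lies well beyond the usual scatter. Still unmeasured is compound 3 `COc1ccc(N(C)c2nc(C)nc3ccccc23)cc1C(=O)OCCC[Se]C#N`. It differs from compound 1 in one place: a group of 4 heavy atoms (2 carbon, 1 nitrogen, 1 selenium; no ring) in place of a group of 3 heavy atoms (1 carbon, 1 nitrogen, 1 selenium; no ring), on a saturated chain carbon, two bonds along the chain from an oxygen next to a carbonyl group, on a saturated chain carbon, two bonds along the chain from an oxygen next to a carbonyl group. Among the compounds with values here, no pair of measured compounds shows a step of this kind, so the expectation rests on the modest size of the change alone: no step beyond the scatter in this assay, in either direction. For compound 3 the expected value is 300 nM, with an estimated range from 100 nM to 900 nM, which amounts to an expected 1.2-fold lower number from compound 1 to compound 3 (0.07 log units; within the scatter).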

Compound 3, half-maximal inhibitory concentration: 250 nM
The estimate for compound 3 lay 1.2-fold (0.08 log units) above the measured number; the measured number falls inside the stated range.
By their numbers in this assay, from the lowest: compound 2; then compounds 3 and 1 (each within the scatter of the next).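

At this position, on a saturated chain carbon, two bonds along the chain from an oxygen next to a carbonyl group, a group of 4 heavy atoms (2 carbon, 1 nitrogen, 1 selenium; no ring) replaces a group of 3 heavy atoms (1 carbon, 1 nitrogen, 1 selenium; no ring). In this assay this gives a 1.4-fold lower number from compound 1 to compound 3 (0.15 log units; within the scatter), so the read-out does not separate the two compounds, and this small change on the core of compound 1 is tolerated. No supporting measurement is available to explain this outcome.

As far as these compounds go, whether a longer chain would also stay within the scatter remains open. So does the effect of placing an amine or a carboxylic acid at this position instead.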